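Aryl exchange on the shared core: notes toward compound 3

This account rests on a few compounds, and the source may have more. Where it says the series, first, only, none or still open, it means among the compounds named here.

Of the compounds shown here, two have been measured in a functional assay on BGC-823 cells (Homo sapiens) for antiproliferative activity, read by MTT assay, tested at 1 uM; on this read-out higher numbers stand for a stronger effect at the one concentration tested and lower numbers for a weaker effect. Compound 1 `COc1cc(C(=O)N/N=C/c2ccc(F)c(F)c2)cc(OC)c1OC` gives 33.1% in this assay. Compound 2 `COc1cc(C2=NN(C(C)=O)C(c3ccccc3C(F)(F)F)O2)cc(OC)c1OC` gives 31.8% in this assay. Compound 2 holds the lower of the two numbers, yet compound 1, its nearest neighbour, sits within the scatter of it, so the two values cannot be ranked and neither compound can be called the more or less active of the pair.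

Compound 3 `COc1ccc(OC)c(C2OC(c3cc(OC)c(OC)c(OC)c3)=NN2C(C)=O)c1` has not yet been measured in this assay. It differs from compound 2 in one place: 2,5-dimethoxyphenyl in place of 2-(trifluoromethyl)phenyl on a saturated ring carbon. For the measured compounds named here, no step between two measured compounds is available for this exchange, so its size cannot be read from the data. Both measured values lie close together, and on that basis the step from compound 2 to compound 3 is expected to be small, in either direction, and probably not beyond the scatter.

In this assay compound 3 is expected to give about 32%, estimated between 15% and 50%. This estimate means an expected step of a number 0.2 percentage points higher from compound 2 to compound 3 (within the scatter).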

Compound 3, a percentage reported as inhibition, at one concentration (the size of the read-out at that concentration, not a potency): 0.4%
Compound 3: middle estimate off by 31.6 percentage points, on the high side; measured number outside the range, below it.
By their numbers in this assay, from the lowest: compound 3; then compounds 2 and 1 (each within the scatter of the next).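

In this assay, for the compounds shown here, placing 2,5-dimethoxyphenyl instead of 2-(trifluoromethyl)phenyl on the saturated ring carbon gives a number 31.4 percentage points lower from compound 2 to compound 3 (beyond the scatter), the first step that can be read as a real change and a large one. The aryl group on this carbon is therefore not freely exchangeable on the shared core, and at the one concentration tested the read-out depends strongly on which aryl group sits there. The large step occurs although the two groups match in heavy-atom count and in ring type, differing in their elements and hydrogen-bond acceptors, and nothing measured on the compounds explains the step or assigns it to any one of these differences.

The compounds shown leave open whether the step follows from the arrival of the methoxy groups or the departure of trifluoromethyl, a question that unsubstituted phenyl or a phenyl with a single methoxy group on this carbon could help to separate. Also open, going by these compounds, is whether a phenyl bearing chlorine or a dimethylamino group would give a number near that of compound 2 or near that of compound 3.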